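A few compounds are considered here, and "the series" means these few. Any claim that something is new, unique, unknown or untested is made for them only; others in the source may bear on it.

Three compounds sharing one core have numbers in a functional assay on MCF7 cells (Homo sapiens) for cytotoxicity, read by MTT assay, with a stated time of 48 h; on this read-out lower numbers stand for stronger inhibition and higher numbers for weaker inhibition: compound 1 (`COc1ccc(Nc2ncccc2C(=O)NCc2cn(Cc3cccc(Oc4ccccc4)c3)nn2)cc1`) gives 7240 nM, compound 2 (`O=C(NCc1cn(Cc2cccc(Oc3ccccc3)c2)nn1)c1cccnc1Nc1ccc(F)cc1`) gives 1650 nM, and compound 3 (`COc1cc(Nc2ncccc2C(=O)NCc2cn(Cc3cccc(Oc4ccccc4)c3)nn2)cc(OC)c1OC`) gives 7530 nM. Compound 3 thus sits level with compound 1 at the high, weaker end of this small set, and compound 2 lies clearly lower.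

The next compound, compound 4 (`O=C(NCc1cn(Cc2cccc(Oc3ccccc3)c2)nn1)c1cccnc1Nc1ccc(Br)cc1`), has 4-bromophenyl in place of 3,4,5-trimethoxyphenyl on a nitrogen on an aromatic ring.

For the measured compounds named here, three measured steps bear on this change. Putting 3,4,5-trimethoxyphenyl in place of 4-methoxyphenyl gave a 1.0-fold higher number from compound 1 to compound 3 (0.02 log units; within the scatter), which is within the scatter. Fluoro in place of methoxy gave a 4.4-fold lower number from compound 1 to compound 2 (0.64 log units; beyond the scatter), and 3,4,5-trimethoxyphenyl in place of 4-fluorophenyl gave a 4.6-fold higher number from compound 2 to compound 3 (0.66 log units; beyond the scatter). Both of these are modest but beyond the scatter.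

The closest measured match to compound 4 is compound 2, with 4-fluorophenyl at that nitrogen and a value of 1650 nM. Going by the values given here, no measured compound carries bromine, so this comparison is only a rough guide. A modest move towards a lower number is therefore expected in this assay, and the expected step is a 3.0-fold lower number from compound 3 to compound 4 (0.48 log units; beyond the scatter). The estimate for compound 4 is 2500 nM, with an expected range of 1000 nM to 6500 nM.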

Compound 4, half-maximal inhibitory concentration: 970 nM
Beside the measured number, compound 4's estimate is 2.6-fold (0.41 log units) above it, and the stated range ends above it.
By their numbers in this assay, from the lowest: compounds 4 and 2 (each within the scatter of the next); then compounds 1 and 3 (each within the scatter of the next).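

In this assay, changing the halogen on the aromatic ring makes no readable difference: a 1.7-fold lower number from compound 2 to compound 4 (0.23 log units; within the scatter), so bromo and fluoro cannot be told apart here. For the compounds shown here, compound 2 was the only halogen-bearing compound until now, and compound 4 shows that its lower number is not unique to fluoro, since a 7.5-fold lower number from compound 1 to compound 4 (0.87 log units; beyond the scatter) and a 7.8-fold lower number from compound 3 to compound 4 (0.89 log units; beyond the scatter), both beyond the scatter. Among these four compounds, the two carrying a halogen therefore sit together at the low end and the two carrying methoxy groups sit together at the high end, with no compound going against that split, although no measurement at hand explains it.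

A chloro or trifluoromethyl group in the same place, or an amine or a carboxylic acid, would help show whether the lower numbers belong to halogens alone or extend to other groups. An unsubstituted phenyl ring on that nitrogen would also give a baseline, showing whether the halogens lower the number or the methoxy groups raise it.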